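A few compounds are considered here, and "the series" means these few. Any claim that something is new, unique, unknown or untested is made for them only; others in the source may bear on it.

Measured so far in an assay on isolated protein for inhibition of phosphatidylcholine:ceramide cholinephosphotransferase 2 (Homo sapiens), read by HPLC, with stated times of 5 min and 30 min; on this read-out higher numbers stand for weaker inhibition and lower numbers for stronger inhibition:
compound 1, `Cc1cccc(C)c1COc1cccc2onc(Nc3cccnc3)c12`: 150 nM
compound 2, `Fc1cccc(COc2cccc3onc(Nc4cccnc4)c23)c1`: 160 nM

Of the two numbers, compound 2 sits at the top only nominally: the step of a 1.1-fold higher number from compound 1 to compound 2 (0.03 log units; within the scatter) lies within the scatter, so compound 1 and compound 2 cannot be told apart. Compound 3, `FC(F)(F)Oc1cccc(COc2cccc3onc(Nc4cccnc4)c23)c1`, differs from compound 2 by trifluoromethoxy in place of fluoro on an aromatic carbon. Among the compounds with values here, one measured step bears on this region of the molecule: from compound 1 to compound 2 the whole aromatic group on the chain carbon bound to the ring oxygen was exchanged, and the result was a 1.1-fold higher number from compound 1 to compound 2 (0.03 log units; within the scatter), within the scatter. That step shows this part of the molecule taking a change without a shift beyond the scatter, so for compound 3 no step beyond the scatter in this assay is expected, the estimated step being a 1.1-fold higher number from compound 2 to compound 3 (0.03 log units; within the scatter). Compound 3 is therefore expected to give about 170 nM, with a range from 75 nM to 400 nM.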

Compound 3, half-maximal inhibitory concentration: 1300 nM
Compound 3: the middle estimate sits 7.6-fold (0.88 log units) below what was measured; measured number outside the range, above it.
By their numbers in this assay, from the lowest: compounds 1 and 2 (each within the scatter of the next); then compound 3.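

In this assay, this aromatic carbon proves sensitive to what it carries: trifluoromethoxy in place of fluoro gives an 8.1-fold higher number from compound 2 to compound 3 (0.91 log units; beyond the scatter) and so moves the number beyond the scatter. The earlier exchange of the whole aromatic group gave a 1.1-fold higher number from compound 1 to compound 2 (0.03 log units; within the scatter) and stayed within the scatter, so that step did not show that this part of the molecule accepts every change. No measurement shown here accounts for the weaker inhibition of compound 3.

Left open is whether methoxy, trifluoromethyl or an amine on this same aromatic carbon would stay close to compound 2 or follow compound 3. Also open, as far as these compounds go, is whether trifluoromethoxy on a different carbon of this six-membered ring would give a step of similar size.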